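This account rests on a few compounds, and the source may have more. Where it says the series, first, only, none or still open, it means among the compounds named here.

Measured so far in an ADME assay on microsomes from liver (Mus musculus) for pharmacokinetics, read by LC-MS, using NADPH, with stated times of 5 min, 15 min and 30 min, tested at 10 uM; a higher number here means faster removal of the compound, a lower number slower removal:
Compound 1 `C[C@H](NC(=O)C1CCOCC1)c1ccc(NC(=O)N2CC(c3cccnc3)C2)cc1`: 58 mL.min-1.g-1
Compound 2 `C[C@H](NC(=O)c1cccc(F)c1)c1ccc(NC(=O)N2CC(c3cncc(N)c3)C2)cc1`: 27.4 mL.min-1.g-1
Compound 3 `C[C@H](NC(=O)c1ncccn1)c1ccc(NC(=O)N2CC(c3cncc(N)c3)C2)cc1`: 83.4 mL.min-1.g-1

Compound 3 lies within the scatter of compound 1, while its number is higher than that of compound 2 by a margin beyond the scatter.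

Compound 4 `C[C@H](NC(=O)C1CCOCC1)c1ccc(NC(=O)N2CC(c3cncc(N)c3)C2)cc1` comes from compound 3 by a single change: oxan-4-yl in place of pyrimidin-2-yl on a carbonyl carbon. This places oxan-4-yl in place of pyrimidin-2-yl on a carbonyl carbon.

Going by the values given here, one measured step bears directly on this position: a 3.0-fold higher number from compound 2 to compound 3 (0.48 log units; beyond the scatter). It is modest, and it involves a different incoming group, so it shows that this position can move the number but does not give the size of this change. Compound 1 also carries oxan-4-yl on a carbonyl carbon and differs from compound 4 elsewhere. Compound 1 gives 58 mL.min-1.g-1.

The expected change is small and downward, and no step beyond the scatter is expected: a 1.7-fold lower number from compound 3 to compound 4 (0.22 log units; within the scatter).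

For compound 4 the estimated value is 50 mL.min-1.g-1, with an expected range of 25 mL.min-1.g-1 to 100 mL.min-1.g-1.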

Compound 4, intrinsic clearance in microsomes: 60.2 mL.min-1.g-1
For compound 4 the middle estimate is 1.2-fold (0.08 log units) below the measured one; low and high end bracket the measured number.
By their numbers in this assay, from the lowest: compound 2; then compounds 1, 4 and 3 (each within the scatter of the next).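

In this assay, three groups can now be compared on a carbonyl carbon with the rest of the structure held constant: a 1.4-fold lower number from compound 3 to compound 4 (0.14 log units; within the scatter) shows that oxan-4-yl and pyrimidin-2-yl cannot be told apart, whereas a 2.2-fold higher number from compound 2 to compound 4 (0.34 log units; beyond the scatter) sets oxan-4-yl apart from 3-fluorophenyl, so among these three compounds only 3-fluorophenyl stands apart. With oxan-4-yl held fixed, a 1.0-fold higher number from compound 1 to compound 4 (0.02 log units; within the scatter) shows that amino in place of hydrogen on an aromatic carbon makes no difference beyond the scatter for this pair. No measurement shown here accounts for these steps.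

Going by these compounds, how a longer alkyl chain or a carboxylic acid would read on this carbonyl carbon remains open. Also open, on these data alone, is whether the amino step holds with pyrimidin-2-yl or 3-fluorophenyl in that place.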